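Benzyl to methyl on the shared core

The compounds below may be only part of what the source reports. "The series", "measured", "known", "first", "only" and "open" are said of these compounds alone.

Values from an in vitro ADME assay on microsomes from liver (Homo sapiens) for metabolic stability (on this read-out lower numbers stand for slow clearance and higher numbers for fast clearance), so far
- compound 1 `NC(=O)c1n[nH]c(-c2nc(Cc3ccccc3F)c3ccccn23)n1` gives < 8 mL.min-1.g-1 (a limit of the assay, not a number)
- compound 2 `Fc1ccccc1Cc1nc(-c2nc(Cc3ccccc3)n[nH]2)n2ccccc12` gives "not determined" (no result reported) (no result)

Compound 2 therefore offers no number as a starting point. Compound 3 `Cc1n[nH]c(-c2nc(Cc3ccccc3F)c3ccccn23)n1` is the next structure. The change hydrogen in place of phenyl on a saturated chain carbon bound to an aromatic carbon puts hydrogen in place of phenyl on a saturated chain carbon bound to an aromatic carbon, which reads as benzyl to methyl. For the measured compounds named here, no step of this kind has been measured, so no size or direction of step in this assay can be stated. Going by the values given here, the only anchor is compound 1, whose limit is < 8 mL.min-1.g-1 in the same assay. Compound 3 is estimated at 10 mL.min-1.g-1 with an expected range of 5 mL.min-1.g-1 to 25 mL.min-1.g-1 in this read-out.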

Compound 3, intrinsic clearance in microsomes: 124 mL.min-1.g-1
Estimate against measurement, compound 3: 12-fold (1.09 log units) below; the whole stated range lies below it.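

In this assay the aromatic carbon carrying carbamoyl in compound 1 and methyl in compound 3 proves highly sensitive, with the change giving an at least 15-fold higher number from compound 1 to compound 3 (1.19 log units; beyond the scatter) on the shared core. For the compounds shown here, this is the first readable step. It is a bound rather than a size, as compound 1 stands at a limit of the assay, not a number: the limit of < 8 mL.min-1.g-1 in this assay, at which 1 of the 3 values shown sits.

The benzyl to methyl step from compound 2 cannot be read, as compound 2 has no result. As far as these compounds go, whether a primary amine or a carboxylic acid on that aromatic carbon would give a low clearance like that of compound 1 remains open.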